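Replacing the arylthiourea of compound 2 by (2-carboxyethyl)carbonyl

The source may hold more compounds than are shown below. What is called first, only, known or untested is meant among the compounds shown, and "the series" means these compounds.

Measured compounds:
compound 1 `CCCCNC(=S)NC1=C(C#N)C(c2ccc(Cl)cc2Cl)C2=C(CCCC2=O)N1c1ccc(S(N)(=O)=O)cc1` gives 40%
compound 2 `N#CC1=C(NC(=S)Nc2ccccc2)N(c2ccc(S(N)(=O)=O)cc2)C2=C(C(=O)CCC2)C1c1ccc(Cl)cc1Cl` gives 95%
compound 3 `N#CC1=C(NC(=S)Nc2ccc(Cl)cc2)N(c2ccc(S(N)(=O)=O)cc2)C2=C(C(=O)CCC2)C1c1ccc(Cl)cc1Cl` gives 100%

In a functional assay on Ehrlich cells (Mus musculus) for cytotoxicity, read by trypan blue exclusion, with a stated time of 2 h, tested at 100 ug/mL (on this read-out lower numbers stand for a weaker effect and higher numbers for a stronger effect at the one concentration tested), compound 2 sits together with compound 3, the step of a number 5 percentage points higher from compound 2 to compound 3 (within the scatter) being within the scatter, and far above compound 1, as shown by a number 55 percentage points higher from compound 1 to compound 2 (beyond the scatter).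

Compound 4 `N#CC1=C(NC(=O)CCC(=O)O)N(c2ccc(S(N)(=O)=O)cc2)C2=C(C(=O)CCC2)C1c1ccc(Cl)cc1Cl` is the next member. Its change against compound 2: a group of 7 heavy atoms (4 carbon, 3 oxygen; no ring) in place of a group of 9 heavy atoms (7 carbon, 1 nitrogen, 1 sulfur; one six-membered aromatic ring of carbon only), on an amine nitrogen

Among the measured compounds shown here, two measured steps bear on this. a number 55 percentage points higher from compound 1 to compound 2 (beyond the scatter) and a number 60 percentage points higher from compound 1 to compound 3 (beyond the scatter) show that the butyl analogue compound 1, whose group carries no ring, stands far below both aryl analogues. The group entering in compound 4 also has no ring, so a large downward step is expected, a number 45 percentage points lower from compound 2 to compound 4 (beyond the scatter). For the measured compounds named here, no measured pair tests thiourea against amide, so the range is wide.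

Compound 4 is estimated at 50%, between 25% and 85%.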

Compound 4, a percentage reported as activity, at one concentration (the size of the read-out at that concentration, not a potency): 60%
Beside the measured number, compound 4's estimate is 10 percentage points below it, and the stated range covers the measured number.
By their numbers in this assay, from the lowest: compound 1; then compound 4; then compounds 2 and 3 (each within the scatter of the next).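

In this assay, a group without a ring on this amine nitrogen again gives a large drop from the aryl thioureas, seen in a number 35 percentage points lower from compound 2 to compound 4 (beyond the scatter) and in a number 40 percentage points lower from compound 3 to compound 4 (beyond the scatter). Even so, a number 20 percentage points higher from compound 1 to compound 4 (beyond the scatter) shows that groups without a ring do not all read alike here, so the absence of a ring does not alone set the level. No measurement available here explains these differences.

Still open, as far as these compounds go, is whether a phenyl amide on this nitrogen would stay level with compound 2, which would separate the ring from the thiourea. Also open, from the compounds shown here alone, is whether the carboxylic acid itself matters, as against its methyl ester or a longer chain.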